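From Fluoropyridine to Cyanophenyl on a Shared Core

A few compounds are considered here, and "the series" means these few. Any claim that something is new, unique, unknown or untested is made for them only; others in the source may bear on it.

Of the compounds shown here, three have so far been measured in an assay on HEK293 cells for activation of Kir3.1/Kir3.2 (Homo sapiens), read by thallium flux; on this read-out higher numbers stand for an effect only at larger amounts of compound and lower numbers for an effect already at smaller amounts. Compound 1 `O=C(Cn1nnc(-c2ccccc2)n1)NC1CC2CCC1C2` gives 1980 nM. Compound 2 `Cc1cc(NC(=O)Cn2nnc(-c3ccccc3)n2)n(C2CCS(=O)(=O)CC2)n1` reaches only a limit of the assay, > 10000 nM; this is the limit of > 10000 nM in this assay, at which 1 of the 3 values shown sits. Compound 3 `Cc1cc(NC(=O)Cn2nnc(-c3ccnc(F)c3)n2)n(C2CCCCC2)n1` gives 441 nM, the lowest of the two numbers; the nearest, compound 1, sits higher by a margin beyond the usual scatter. Compound 4 `Cc1cc(NC(=O)Cn2nnc(-c3cccc(C#N)c3)n2)n(C2CCCCC2)n1` has not yet been measured. It differs from compound 3 in one place (3-cyanophenyl in place of 2-fluoropyridin-4-yl on an aromatic carbon). Going by the values given here, no measured pair shows an exchange of this kind, so the expected step in this assay is estimated as small, no larger than the scatter, a 1.6-fold higher number from compound 3 to compound 4 (0.20 log units; within the scatter). Compound 4 is accordingly expected to give about 700 nM, somewhere between 200 nM and 3000 nM.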

Compound 4, half-maximal effective concentration: 183 nM
Compound 4: middle estimate off by 3.8-fold (0.58 log units), on the high side; the measured number lies below the stated range.
By their numbers in this assay, from the lowest: compound 4; then compound 3; then compound 1. At a limit, above all of these: compound 2.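

Replacing 2-fluoropyridin-4-yl with 3-cyanophenyl gives a 2.4-fold lower number from compound 3 to compound 4 (0.38 log units; beyond the scatter) in this assay, so this position on the shared core responds to the exchange. A ring nitrogen at this position is not required, since the ring of carbon only with its nitrile gives the lower number. Nothing measured here gives a reason for this step.

As far as these compounds go, the exchange alters the ring and its substituent together, so the share of each stays open. From the compounds shown here alone, how an amine or a carboxylic acid in place of the nitrile would read also remains unknown.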